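Methyl in place of trifluoromethyl: the step to compound 4

This account rests on a few compounds, and the source may have more. Where it says the series, first, only, none or still open, it means among the compounds named here.

Measured so far in a functional assay on HeLa cells (Homo sapiens) for antiproliferative activity, with a stated time of 24 h; on this read-out lower numbers stand for stronger inhibition and higher numbers for weaker inhibition:
compound 1 `NC(=O)c1c(NC(=O)c2ccccc2Cl)sc2c1CCN(C(=S)Nc1ccccc1C(F)(F)F)C2`: 26700 nM
compound 2 `Cc1ccccc1NC(=S)N1CCc2c(sc(NC(=O)c3ccccc3Cl)c2C(N)=O)C1`: > 50000 nM
compound 3 `Cc1ccccc1C(=O)Nc1sc2c(c1C(N)=O)CCN(C(=S)Nc1ccccc1C(F)(F)F)C2`: > 50000 nM

For the measured compounds named here, compound 1 is the only member with a number in this assay, where compound 1 gives 26700 nM. For compound 2 the assay gives only a limit, > 50000 nM. For compound 3 likewise only a limit is reported, > 50000 nM.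

Two changes lead away from compound 1. The first, (methyl in place of trifluoromethyl on an aromatic carbon), gives an at least 1.8-fold higher number from compound 1 to compound 2 (0.27 log units; that floor lies within the scatter). The second, (methyl in place of chloro on an aromatic carbon), gives an at least 1.8-fold higher number from compound 1 to compound 3 (0.27 log units; that floor lies within the scatter). Both steps end at a limit, so their true size is open.

Compound 4 `Cc1ccccc1NC(=S)N1CCc2c(sc(NC(=O)c3ccccc3C)c2C(N)=O)C1` is not yet measured. It differs from compound 3 by methyl in place of trifluoromethyl on an aromatic carbon. The place wording is the same as for the change from compound 1 to compound 2, so this is the same change, carried onto a different core; the two cores differ by methyl in place of chloro on an aromatic carbon.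

Compound 3 already sits at the limit, and the same change once gave an at least 1.8-fold higher number from compound 1 to compound 2 (0.27 log units; that floor lies within the scatter); beside that, a step that the limit leaves unreadable from compound 3 to compound 4 is expected here. Compound 4 is therefore expected to be reported as a limit as well because the limit of > 50000 nM in this assay, at which 2 of the 3 values shown sit, already holds most of this set. Compound 4 is estimated at 100000 nM, with a likely range for compound 4 from 40000 nM to 300000 nM.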

Compound 4, half-maximal inhibitory concentration: > 50000 nM
Compound 4: a limit, no number; the forecaster's own chance of this, stated with the estimate: 85%; the middle value does not contradict the limit.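

In this assay compound 4 gives > 50000 nM, a limit and not a number. Its steps from compound 3 and from compound 2 therefore cannot be read, as each joins two limits. The series now rests largely on one value: the limit of > 50000 nM in this assay, at which 3 of the 4 values shown sit.

Still open, as far as these compounds go, is the true potency of compound 2, compound 3 and compound 4, and so the size of methyl in place of trifluoromethyl on the core of compound 3.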